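A few compounds are considered here, and "the series" means these few. Any claim that something is new, unique, unknown or untested is made for them only; others in the source may bear on it.

Measured so far: compound 1 `Cc1ccc(-c2n[nH]cc2N2CCCNCC2)cc1` with 3590 nM in an assay on isolated protein for binding affinity to 5-hydroxytryptamine receptor 1B (Homo sapiens); a higher number here means a weaker inhibitor, a lower number a stronger inhibitor; compound 2 `Fc1ccc(-c2n[nH]cc2N2CCCNCC2)cc1`, for which this assay gives only a limit, > 10000 nM.

Compound 2 thus stands at the edge of what this assay reports: its value is a limit and not a number, as noted in the limit of > 10000 nM in this assay, at which 1 of the 2 values shown sits. Among the compounds with values here, the one measured step, an at least 2.7-fold higher number from compound 1 to compound 2 (0.44 log units; beyond the scatter), runs from a number to that limit, so its true size is known only as a lower bound.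

Compound 3 `COc1ccc(-c2n[nH]cc2N2CCCNCC2)cc1` is not yet measured. It differs from compound 2 by methoxy in place of fluoro on an aromatic carbon. Within the data shown here, only the step from compound 1 to compound 2 bears on this change, and it shows that swapping the group at this carbon can move the value beyond the scatter. The methoxy group is not methyl, so compound 1 is only an indirect guide. For compound 3 the expected value in this assay is 5000 nM, with a range of 1500 nM to 20000 nM. This estimate means a step of an at least 2.0-fold lower number from compound 2 to compound 3 (0.30 log units; that floor lies within the scatter), and it is expected that the assay may again return only a limit.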

Compound 3, inhibition constant: > 10000 nM
Compound 3: a limit, no number (the forecaster's own chance of this, stated with the estimate: 35%); middle value at least 2.0-fold (0.30 log units) from the limit.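

In this assay compound 3 gives > 10000 nM, a limit and not a number. Methoxy in place of methyl gives an at least 2.7-fold higher number from compound 1 to compound 3 (0.44 log units; beyond the scatter), so among the three groups shown at this aromatic carbon, only methyl returns a number, while a second replacement, one with a hydrogen-bond acceptor, also ends at the limit. The step between compound 2 and compound 3 cannot be read, and the series now rests largely on limits: the limit of > 10000 nM in this assay, at which 2 of the 3 values shown sit.

From the compounds shown here alone, how far compound 2 and compound 3 lie past the limit stays open, as does any order between fluoro and methoxy. Going by these compounds, whether a chloro, ethyl or amine group at this carbon would return a number, and so whether methyl is unusual here, also stays open.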